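A few compounds are considered here, and "the series" means these few. Any claim that something is new, unique, unknown or untested is made for them only; others in the source may bear on it.

Of the compounds shown here, three of the shared core have been measured in an assay on isolated protein for inhibition of DNA topoisomerase 1 (Homo sapiens), with a stated time of 30 min, tested at 100 uM; a higher number here means a stronger effect of the compound at the concentration tested, a lower number a weaker effect. Compound 1 `Oc1ccc(-c2cc(-c3ccsc3)cc(-c3cccc(O)c3)n2)cc1` gives 17.1%, compound 2 `Oc1ccc(-c2cc(-c3ccsc3)cc(-c3ccc(O)cc3)n2)cc1` gives 61.7%, and compound 3 `Oc1ccc(-c2cc(-c3ccccn3)cc(-c3cccc(O)c3)n2)cc1` gives 2.4%, the lowest of the three. Compound 1 and compound 2 differ by 4-hydroxyphenyl in place of 3-hydroxyphenyl on an aromatic carbon, with a step of a number 44.6 percentage points higher from compound 1 to compound 2 (beyond the scatter). The cores of compound 1 and compound 3 differ by pyridin-2-yl in place of thiophen-3-yl on an aromatic carbon, with a step of a number 14.7 percentage points lower from compound 1 to compound 3 (beyond the scatter). Compound 4 `Oc1ccc(-c2cc(-c3ccccn3)cc(-c3ccc(O)cc3)n2)cc1` is unmeasured and differs from compound 3 by 4-hydroxyphenyl in place of 3-hydroxyphenyl on an aromatic carbon. The surroundings are not identical: in compound 1 the place is meta to a thiophen-3-yl group, in compound 3 meta to a pyridin-2-yl group, so this is the same kind of change, not the same one. In this assay the expected step is a number 22.6 percentage points higher from compound 3 to compound 4 (beyond the scatter), smaller than a number 44.6 percentage points higher from compound 1 to compound 2 (beyond the scatter), because compound 3 starts from 2.4% on a different core. Compound 4 is estimated at 25%, between 5% and 50%.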

Compound 4, a percentage reported as inhibition, at one concentration (the size of the read-out at that concentration, not a potency): 1.4%
Beside the measured number, compound 4's estimate is 23.6 percentage points above it; measured number below the stated range.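

In this assay, 4-hydroxyphenyl in place of 3-hydroxyphenyl does not carry over from the thiophen-3-yl compounds to the pyridin-2-yl compounds, where the step is a number 1 percentage points lower from compound 3 to compound 4 (within the scatter), so the two steps do not agree: the same change on two cores in this assay, a number 44.6 percentage points higher (beyond the scatter) from compound 1 to compound 2 and a number 1 percentage points lower (within the scatter) from compound 3 to compound 4, 45.6 percentage points apart, beyond the scatter of two such steps.
Pyridin-2-yl in place of thiophen-3-yl, here a number 60.3 percentage points lower from compound 2 to compound 4 (beyond the scatter), also depends on the group at the other place: the same change on two cores in this assay, a number 14.7 percentage points lower (beyond the scatter) from compound 1 to compound 3 and a number 60.3 percentage points lower (beyond the scatter) from compound 2 to compound 4, 45.6 percentage points apart, beyond the scatter of two such steps.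
These four compounds show that the two changes do not add up independently here, but they do not show how either change behaves on any other core, or what lies behind the gap.

From the compounds shown here alone, it remains open whether an amine or a carboxylic acid in place of the hydroxyl of compound 2 would keep its number. The same holds for a furan-3-yl group in place of its thiophen-3-yl group.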